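The source may hold more compounds than are shown below. What is called first, only, known or untested is meant among the compounds shown, and "the series" means these compounds.

Measured in a functional assay on HCT-116 cells (Homo sapiens), read by sulforhodamine B assay, with a stated time of 5 days; on this read-out lower numbers stand for stronger inhibition of growth and higher numbers for weaker inhibition of growth:
- compound 1 `OC[C@H]1O[C@@H](n2cc(F)c3c(-c4ccccc4)ncnc32)[C@H](O)[C@@H]1O`: > 10000 nM (a limit)
- compound 2 `OC[C@H]1O[C@@H](n2cc(F)c3c(-c4ccco4)ncnc32)[C@H](O)[C@@H]1O`: 39 nM
- compound 3 `OC[C@H]1O[C@@H](n2cc(F)c3c(-c4c[nH]cn4)ncnc32)[C@H](O)[C@@H]1O`: > 10000 nM (a limit)

Compound 1 has no number, only a limit: it stands at the limit of > 10000 nM in this assay, at which 2 of the 3 values shown sit. The next analogue is compound 4 `OC[C@H]1O[C@@H](n2cc(Cl)c3c(-c4ccccc4)ncnc32)[C@H](O)[C@@H]1O`, with chloro in place of fluoro on an aromatic carbon. The nearest measured steps, an at least 250-fold lower number from compound 1 to compound 2 (2.40 log units; beyond the scatter) and an at least 250-fold higher number from compound 2 to compound 3 (2.40 log units; beyond the scatter), are large, but both exchange the group that is phenyl in compound 1, and neither exchanges the halogen. They give no direct size for this step. Compound 4 keeps the phenyl that gives compound 1 > 10000 nM, a limit, so no step beyond the scatter is expected in this assay. The expected step is a number no higher from compound 1 to compound 4 (the limit leaves the size open). Compound 4 is estimated at 10000 nM, with an expected range of 3000 nM to 30000 nM.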

Compound 4, concentration for 50% growth inhibition: 1400 nM
For compound 4 the middle estimate is 7.1-fold (0.85 log units) above the measured one; the measured number lies below the stated range.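

In this assay, chloro in place of fluoro on an aromatic carbon of the five-membered aromatic ring gives an at least 7.1-fold lower number from compound 1 to compound 4 (0.85 log units; beyond the scatter). Within the data shown here, the earlier steps exchanged only the group that is phenyl in compound 1, so this is the first sign that the halogen position also moves the read-out, and that a phenyl-bearing analogue can give a measurable number. Compound 1 is a limit and not a number, so the full size of this step stays open: the limit of > 10000 nM in this assay, at which 2 of the 4 values shown sit.

As far as these compounds go, whether chloro also lowers the number with furan-2-yl, as in compound 2, remains open. So does the outcome with bromo, methyl or an amine at this position.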